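The source may report more compounds than this note shows. Statements on the series, on what has been measured and on what is new or still open speak of the compounds shown alone.

Measured compounds:
- compound 1 `N#C[C@@H]1CCCN1C(=O)[C@@H]1C[C@H](C(=O)N2CCOCC2)CN1`: 44%
- compound 2 `CCN(CC)C(=O)[C@@H]1CN[C@H](C(=O)N2CCC[C@H]2C#N)C1`: "not determined" (no result reported)
- compound 3 `N#C[C@@H]1CCCN1C(=O)[C@@H]1C[C@H](C(=O)N2CCCCCC2)CN1`: "not determined" (no result reported)

In an assay on the whole organism (plasma, strain Sprague-Dawley) for inhibition of Dipeptidyl peptidase 4 (Rattus norvegicus), with a stated time of 10 h, at a dose of 1 mg/kg by the oral route (on this read-out higher numbers stand for more inhibition at the one dose given (going by the name of the read-out) and lower numbers for less inhibition), compound 1 gives 44%. For compound 2 the result in this assay is "not determined" (no result reported), and for compound 3 the result in this assay is likewise "not determined" (no result reported), so compound 3 stands without a number and nothing can be placed on the read-out relative to compound 1.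

Compound 4 `CCN(C)C(=O)[C@@H]1CN[C@H](C(=O)N2CCC[C@H]2C#N)C1` shares the core of compound 3 and differs only in the amide substituent: ethyl(methyl)amino in place of azepan-1-yl on a carbonyl carbon. Among the compounds with values here, with no number for compound 3, no step in this assay can be computed for this change, and no direction can be drawn from the one measured value, that of compound 1; a step no larger than the usual scatter is assumed here as the working expectation, taking the result of compound 1 as the only anchor.

On that basis compound 4 is expected to give about 42% in this assay, estimated within 15% to 70%.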

Compound 4, a percentage reported as inhibition, in the whole organism at one dose (the size of the read-out at that dose, not a potency): 34%
The estimate for compound 4 lay 8 percentage points above the measured number; measured number inside the range.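

Within the data shown here, replacing morpholin-4-yl with ethyl(methyl)amino on the carbonyl carbon gives the first readable step at this position in this assay, a number 10 percentage points lower from compound 1 to compound 4 (within the scatter), so at this single dose the read-out does not separate the ring-bearing amide from the one with no ring. Steps involving compound 2 or compound 3 cannot be read, as neither has a number. No measured property is available to explain this result.

Going by these compounds, it remains open how this assay would read with a dimethylamino group or a piperidin-1-yl group on this carbonyl carbon, or with a carboxylic acid in place of the amide. A single dose and time point also leave open whether compound 1 and compound 4 would separate under other conditions.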